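Shortening the amine chain of compound 1 on liver cells

The compounds below may be only part of what the source reports. "The series", "measured", "known", "first", "only" and "open" are said of these compounds alone.

Compound 1 `C/C(=N/c1ccnc2cc(Cl)ccc12)NCCCCN1CCCCC1` gives 9.81 ug/mL. Compound 3 `CCN(CC)CCCCN/C(C)=N\c1ccnc2cc(Cl)ccc12` gives 2.68 ug/mL. Compound 2 `Clc1ccc2c(N(CCCN3CCCCC3)/C(=N/CCCN3CCCCC3)c3ccccc3)ccnc2c1` gives 2.45 ug/mL.

In an ADME assay on HepG2 cells (Homo sapiens) for cytotoxicity, read by MTT assay, with a stated time of 48 h (a lower number here means a stronger inhibitor, a higher number a weaker inhibitor), compound 1 stands at the highest number of the three, that is, it is the weakest inhibitor of the group. For the measured compounds named here, its nearest neighbour by number is compound 3, and the step of a 3.7-fold lower number from compound 1 to compound 3 (0.56 log units; beyond the scatter) is the only measured change that speaks to the new compound. Compound 4 `CCN(CC)CCN/C(C)=N\c1ccnc2cc(Cl)ccc12` differs from compound 1 as follows: diethylamino in place of 2-(piperidin-1-yl)ethyl on a saturated chain carbon, two bonds along the chain from an amine nitrogen. Going by the values given here, this change combines the same swap of the ring amine for diethylamino seen between compound 1 and compound 3 with a shortening of the chain by two carbons, and no measured pair shows the effect of the shorter chain on its own. Among the compounds with values here, the only available guide is the modest drop in number from compound 1 to compound 3, so a step of similar size and direction is expected here, with wider uncertainty because the chain length is also altered. Compound 4 is therefore expected to give 3.5 ug/mL, in the range 1.5 ug/mL to 9 ug/mL, a step of a 2.8-fold lower number from compound 1 to compound 4 (0.45 log units; beyond the scatter).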

Compound 4, half-maximal inhibitory concentration: 1.32 ug/mL
The estimate for compound 4 lay 2.7-fold (0.42 log units) above the measured number, outside the stated range (below it).
By their numbers in this assay, from the lowest: compounds 4, 2 and 3 (each within the scatter of the next, the first and the last beyond it); then compound 1.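

With the diethylamino end held fixed, a 2.0-fold lower number from compound 3 to compound 4 (0.31 log units; beyond the scatter) in this assay, the first view of shortening the chain on its own. This step runs in the same direction as the swap of the piperidin-1-yl ring for diethylamino, and the two changes together appear as a 7.4-fold lower number from compound 1 to compound 4 (0.87 log units; beyond the scatter) across the whole change at this position. Nothing available explains why the number falls with either change.

The compounds shown leave open whether the same shortening would lower the number with a piperidin-1-yl group at the chain end, and how a morpholine or pyrrolidine ring there would compare. Compound 2 differs from the others in more than one place, so it cannot separate the effect of either change.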